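Cinnamamide series on the shared core: bromo to methoxy

A few compounds are considered here, and "the series" means these few. Any claim that something is new, unique, unknown or untested is made for them only; others in the source may bear on it.

Working notes. Going by the values given here, compound 2 `O=C(/C=C/c1ccc(Br)cc1)Nc1cc2c(Nc3ccc(F)c(Cl)c3)ncnc2cc1O[C@H]1CCOC1` gives 28200 nM in a functional assay on PC-3 cells (Homo sapiens) for cytotoxicity, read by MTT assay, with a stated time of 72 h (a lower number here means a stronger inhibitor, a higher number a weaker inhibitor), and holds the lowest of the two numbers so far. Compound 3 `COc1cc2ncnc(Nc3ccc(F)c(Cl)c3)c2cc1NC(=O)/C=C/c1cc(OC)c(OC)c(OC)c1` gives 38200 nM in this assay, a gap to compound 2 that lies within the scatter, so no order between the two is read. Compound 1 `COc1cc2ncnc(Nc3ccc(F)c(Cl)c3)c2cc1NC(=O)/C=C/c1ccc(C#N)cc1` is reported as "not active" (no number reported) in this assay with no number. The step to compound 4 `COc1ccc(/C=C/C(=O)Nc2cc3c(Nc4ccc(F)c(Cl)c4)ncnc3cc2O[C@H]2CCOC2)cc1` is methoxy in place of bromo on an aromatic carbon. Among the compounds with values here, no measured pair shows this change, so the size of its step is not known. Given that compound 3 with three methoxy groups gives 38200 nM near compound 2, compound 4 is expected to stay in the same weak range, at 35000 nM (from 12000 nM to 100000 nM), a step of a 1.2-fold higher number from compound 2 to compound 4 (0.09 log units; within the scatter) expected not beyond the scatter.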

Compound 4, half-maximal inhibitory concentration: 2240 nM
Compound 4: middle estimate off by 16-fold (1.19 log units), on the high side, outside the stated range (below it).
By their numbers in this assay, from the lowest: compound 4; then compounds 2 and 3 (each within the scatter of the next).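

Going by these compounds alone, with the rest of the structure fixed, the change from 4-bromophenyl to 4-methoxyphenyl gives the first readable step: in this assay it is a 13-fold lower number from compound 2 to compound 4 (1.10 log units; beyond the scatter). This aromatic carbon is therefore sensitive to its substituent, as a single replacement there moves the number beyond the scatter. Nothing available explains the size of this step.

Open, going by these compounds, is whether the gain tracks methoxy itself or the loss of bromo, which an amine, a hydroxyl or an ethoxy group at this carbon could help separate. Also open, on these data alone, is whether the same replacement gives a step of this size with the methoxy group of compound 3 on the shared core.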